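The source may hold more compounds than are shown below. What is called first, only, known or untested is meant among the compounds shown, and "the series" means these compounds.

Working notes on the series. The shared core is carried by compound 1 `Nc1cc(N)c2nc(-c3ccccc3)c(Oc3ccc(Cl)c(Cl)c3)nc2c1`, compound 2 `CCOC(=O)[C@H](CCC(=O)O)NC(=O)c1ccc(Oc2nc3cc(N)cc(N)c3nc2-c2ccccc2)cc1` and compound 3 `COc1ccc(Sc2nc3cc(N)cc(N)c3nc2-c2ccccc2)cc1`; compound 4 `Nc1cc(N)c2nc(-c3ccccc3)c(Oc3ccc(F)cc3)nc2c1` is not yet measured. In a functional assay on SK-MEL-28 cells (Homo sapiens) for inhibition, read by sulforhodamine B assay, with a stated time of 48 h (on this read-out higher numbers stand for lower toxicity in this test and lower numbers for higher toxicity in this test), compound 2 gives 64600 nM. For compound 1 the read-out in this assay is only a limit, < 100000 nM. For compound 3 the read-out in this assay is likewise only a limit, < 100000 nM. The step that the two limits leave unreadable from compound 1 to compound 3 therefore cannot be read, since the limit of < 100000 nM in this assay, at which 2 of the 3 values shown sit, holds both ends of it. Compound 3 thus stands at a limit and not at a number, and one of the two other values shown is the same limit.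

The change to compound 4 is 4-fluorophenoxy in place of (4-methoxyphenyl)sulfanyl on an aromatic carbon. Going by the values given here, no measured step bears readably on this change, so no direction beyond the scatter can be taken from the data. The expected step of a number no lower from compound 3 to compound 4 (the limit leaves the size open) from compound 3 to compound 4 is taken as none of readable size, with a fair chance that compound 4 is again reported only as a limit. Compound 4 is estimated at 100000 nM, with a range from 40000 nM to 250000 nM.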

Compound 4, concentration lethal to 50% of the cells: < 100000 nM
Compound 4 was reported as a limit (the forecaster's own chance of this, stated with the estimate: 60%); the middle value sits exactly at the limit.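

Compound 1, compound 3 and compound 4 are each reported only as a limit in this assay, so no new step among them can be read: the limit of < 100000 nM in this assay, at which 3 of the 4 values shown sit.

The compounds shown leave open whether 3,4-dichlorophenoxy, (4-methoxyphenyl)sulfanyl or 4-fluorophenoxy on this aromatic carbon changes the read-out at all.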